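Removing the ethyl from the ethoxy oxygen of compound 1

The source may hold more compounds than are shown below. What is called first, only, known or untested is meant among the compounds shown, and "the series" means these compounds.

Compound 1 `CCOC1=C(/C(C)=N/OCC(=O)Nc2ccccc2)N(C)S(=O)(=O)c2ccccc21` stands only at a limit on the numbers available. In a functional assay on THP-1 cells (Homo sapiens) for inhibition, read by ELISA, with stated times of 2 h and 48 h (on this read-out lower numbers stand for stronger inhibition and higher numbers for weaker inhibition), compound 1 gives > 20000 nM, which is a limit of the assay and not a number. Within the data shown here, compound 2 `CCOC1=C(/C(C)=N/OCC(=O)Nc2ccc(OC)cc2)N(C)S(=O)(=O)c2ccccc21` is its sole measured neighbour; in this assay compound 2 gives > 20000 nM, again a limit. Among the measured compounds shown here, the single measured step, a step that the two limits leave unreadable from compound 1 to compound 2, cannot be read because of the limit of > 20000 nM in this assay, at which 2 of the 2 values shown sit. Compound 3 `C/C(=N\OCC(=O)Nc1ccccc1)C1=C(O)c2ccccc2S(=O)(=O)N1C` changes compound 1 in another place: hydrogen in place of ethyl on an oxygen on an unsaturated carbon, so that the ethoxy becomes a hydroxy. No measured step touches that oxygen, and the one step shown carries no size, so nothing here fixes the direction or size of the expected step in this assay. The step from compound 1 to compound 3 is expected to be about a step that the limit leaves unreadable from compound 1 to compound 3, most likely unreadable once more. Compound 3 is estimated at 30000 nM, between 8000 nM and 100000 nM, probably again reported as a limit.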

Compound 3, half-maximal inhibitory concentration: > 20000 nM
Compound 3: only a limit was reported; the forecaster's own chance of this, stated with the estimate: 75%; the middle value does not contradict the limit.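

In this assay compound 3 gives > 20000 nM, a limit and not a number. The step from compound 1 to compound 3 therefore cannot be read, because both compounds sit at the same limit: the limit of > 20000 nM in this assay, at which 3 of the 3 values shown sit.

The compounds shown leave open whether the ethoxy to hydroxy change alters inhibition at all.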